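A few compounds are considered here, and "the series" means these few. Any claim that something is new, unique, unknown or untested is made for them only; others in the source may bear on it.

The measured compounds:
compound 1, `C=C(Br)C(=O)Nc1cccc(-c2cn3nc(-c4ccc(C)cc4)sc3n2)c1`, 1200 nM
compound 2, `C=C(Br)C(=O)Nc1cccc(-c2cn3nc(-c4ccc(Cl)cc4)sc3n2)c1`, 2000 nM
compound 3, `Nc1cccc(-c2cn3nc(-c4ccc(Cl)cc4)sc3n2)c1`, 160000 nM

All three were tested in a functional assay on FM3A cells (Mus musculus) for inhibition, read by cell counting, with a stated time of 2 days; on this read-out higher numbers stand for weaker inhibition and lower numbers for stronger inhibition. Compound 3 stands at the highest number of the three. Its nearest neighbour is compound 2, and the distance between them is an 80-fold higher number from compound 2 to compound 3 (1.90 log units; beyond the scatter), a change in which hydrogen replaces the (1-bromoethenyl)carbonyl on the nitrogen on the aromatic ring. Compound 1 lies further off, with compound 1 giving 1200 nM, whereas compound 3 gives 160000 nM.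

Compound 4, `Cc1ccc(-c2nn3cc(-c4cccc(N)c4)nc3s2)cc1`, keeps the free amine of compound 3 and differs from it in one place: methyl in place of chloro on an aromatic carbon. Among the measured compounds shown here, only one measured step bears on this change, the one from compound 1 to compound 2, which runs the other way round, chloro in place of methyl, and came out at a 1.7-fold higher number from compound 1 to compound 2 (0.22 log units; within the scatter). Reversing it in compound 4 points to a slightly lower number, but no step beyond the scatter is expected in this assay.

Compound 4 is therefore expected to give 100000 nM, with a range from 40000 nM to 250000 nM. The step this estimate implies is a 1.6-fold lower number from compound 3 to compound 4 (0.20 log units; within the scatter).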

Compound 4, half-maximal inhibitory concentration: 5800 nM
Compound 4: the middle estimate sits 17-fold (1.24 log units) above what was measured, outside the stated range (below it).
By their numbers in this assay, from the lowest: compounds 1 and 2 (each within the scatter of the next); then compound 4; then compound 3.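

In this assay, the exchange between 4-chlorophenyl and 4-methylphenyl proves to matter when the nitrogen carries its free hydrogens, with a 28-fold lower number from compound 3 to compound 4 (1.44 log units; beyond the scatter). The size of this change, on an aromatic carbon para to a large group, therefore depends on what the nitrogen carries elsewhere in the molecule: the same change on two cores in this assay, a 1.7-fold higher number (0.22 log units; within the scatter) from compound 1 to compound 2 and a 28-fold higher number (1.44 log units; beyond the scatter) from compound 4 to compound 3, 17-fold (1.22 log units) apart, beyond the scatter of two such steps

Read the other way, taking the (1-bromoethenyl)carbonyl off the nitrogen gives a much smaller step with methyl on the ring, a 4.8-fold higher number from compound 1 to compound 4 (0.68 log units; beyond the scatter), than with chloro, so the two places do not act independently of each other: the same change on two cores in this assay, an 80-fold higher number (1.90 log units; beyond the scatter) from compound 2 to compound 3 and a 4.8-fold higher number (0.68 log units; beyond the scatter) from compound 1 to compound 4, 17-fold (1.22 log units) apart, beyond the scatter of two such steps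

The compounds shown hold only chloro and methyl at this ring position, so it stays open whether fluoro, methoxy or plain hydrogen there would give a number closer to compound 3 or to compound 4 on the free amine. Going by these compounds, it also stays open whether an acetyl group on the nitrogen, without the bromine and the ethenyl part, would give numbers like those of compound 1 and compound 2.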